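The source may report more compounds than this note shows. Statements on the series, on what has been measured and on what is new or still open speak of the compounds shown alone.

Measured in an ADME assay (liver) for metabolic stability, with Liver microsome (Rattus norvegicus) as the target, using microsomes; on this read-out lower numbers stand for slow clearance and higher numbers for fast clearance:
- Compound 1 `O=C(O)c1csc(-n2nc(-c3ccccc3)c3c2CCCC3)n1`: 290 mL/min/kg
- Compound 2 `O=C(O)c1csc(-n2nc(-c3ccccc3)c3ccncc32)n1`: 69 mL/min/kg
- Compound 3 `O=C(O)c1csc(-n2nc(-c3ccc(F)cc3)c3ccccc32)n1`: 278 mL/min/kg

Compound 3 reads 278 mL/min/kg, level with compound 1 within the usual scatter of repeat measurements and clearly apart from compound 2 at 69 mL/min/kg, the lowest of the three.

Compound 4 `CC1CCN(c2nn(-c3nc(C(=O)O)cs3)c3ccccc23)CC1` differs from compound 3 in one place: 4-methylpiperidin-1-yl stands in place of 4-fluorophenyl on an aromatic carbon (4-methylpiperidin-1-yl in place of 4-fluorophenyl on an aromatic carbon). The swap keeps the 4-carboxy-1,3-thiazol-2-yl group and the shared core.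

Going by the values given here, no two measured compounds differ in just one place, so nothing here shows directly what a swap of this kind does in this assay. Among the compounds with values here, the only guide is the general level. Compound 1 at 290 mL/min/kg and compound 3 at 278 mL/min/kg read alike although their structures differ in more than one place, while compound 2 goes against that high level. Compound 4 shares its core with compound 3, so it is expected to stay high, with at most a modest fall that does not go beyond the scatter.

The expected change is a 1.4-fold lower number from compound 3 to compound 4 (0.14 log units; within the scatter), which is an estimate with wide uncertainty. For compound 4 the estimated clearance is 200 mL/min/kg, with a likely range of 85 mL/min/kg to 420 mL/min/kg.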

Compound 4, clearance: 260 mL/min/kg
For compound 4 the middle estimate is 1.3-fold (0.11 log units) below the measured one; measured number inside the range.
By their numbers in this assay, from the lowest: compound 2; then compounds 4, 3 and 1 (each within the scatter of the next).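

In this assay, going by these compounds alone, placing 4-methylpiperidin-1-yl in place of 4-fluorophenyl on the aromatic carbon of the five-membered ring gives a 1.1-fold lower number from compound 3 to compound 4 (0.03 log units; within the scatter) and so provides the first direct reading of a single change: at this position, the two groups cannot be told apart on this clearance read-out. The exchange is not a small one on paper, since one six-membered aromatic ring of carbon only leaves and a six-membered non-aromatic ring with a hetero atom and a hydrogen-bond acceptor enters, while the heavy-atom count stays the same and neither group carries a net charge. No measurement presented here offers an explanation for this result.

Within the data shown here, this single step cannot show whether the position is insensitive in general, as it covers only two groups, and a primary amine, a carboxylic acid or a longer alkyl chain at the same carbon could read differently. On these data alone, whether the same swap would also leave the number within the scatter on a different core remains open, as the step rests on the shared core of these two compounds alone.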